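The source may hold more compounds than are shown below. What is called first, only, known or untested is meant among the compounds shown, and "the series" means these compounds.

Measured in a functional assay on MCF7 cells (Homo sapiens) for cytotoxicity, read by WST assay, with a stated time of 72 h; a higher number here means a weaker inhibitor, a lower number a stronger inhibitor:
- Compound 1 `CCCC1(c2ccc(O)cc2)C(=O)Nc2c1ccc(F)c2F`: > 1000 nM
- Compound 2 `O=C1Nc2c(ccc(F)c2F)C1(c1ccc(O)cc1)C1CCCCC1`: 13 nM; 18 nM; > 1000 nM (3 entries)

Compound 1 gives > 1000 nM, which is a limit of the assay and not a number. Compound 3 `O=C1Nc2c(ccc(F)c2F)C1(c1ccc(O)cc1)C1CCCCCCC1` carries cyclooctyl in place of propyl on a saturated ring carbon of the core of compound 1: cyclooctyl in place of propyl on a saturated ring carbon. Compound 2 is the closest measured comparison, but its entries disagree: the several entries of compound 2 in this assay, 13 nM; 18 nM; > 1000 nM (3 entries). Most of those entries point to strong inhibition, so a large gain in this assay is expected, an at least 33-fold lower number from compound 1 to compound 3 (1.52 log units; beyond the scatter). Because of the several entries of compound 2 in this assay, 13 nM; 18 nM; > 1000 nM (3 entries) the expected range stays wide. For compound 3 the estimated value is 30 nM, with an expected range from 6 nM to 400 nM.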

Compound 3, half-maximal inhibitory concentration: > 1000 nM
Compound 3 gave a limit, no number; the forecaster's own chance of this, stated with the estimate: 20%; at least 33-fold (1.52 log units) between middle value and limit.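

For the compounds shown here, compound 1 and compound 3 each give only a limit and not a number, so no step between them can be read. The compounds shown leave open how far cyclooctyl and propyl on a saturated ring carbon truly differ in strength.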